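This account rests on a few compounds, and the source may have more. Where it says the series, first, only, none or still open, it means among the compounds named here.

Compound 1 `COc1cc2c(Oc3ccc(NC(=O)c4cc(-c5cccc(Cl)c5)nc5ccc(F)cc45)cc3F)ccnc2cc1OCCCN1CCC(C)CC1`: 110 nM
Compound 2 `COc1cccc(-c2cc(C(=O)Nc3ccc(Oc4ccnc5cc(OCCCN6CCC(C)CC6)c(OC)cc45)c(F)c3)c3cc(F)ccc3n2)c1`: 840 nM

In a functional assay on U-87MG ATCC cells (Homo sapiens) for cytotoxicity, read by MTT assay, with a stated time of 72 h (on this read-out lower numbers stand for stronger inhibition and higher numbers for weaker inhibition), compound 2 gives 840 nM, the highest of the two numbers measured here. Its nearest measured neighbour is compound 1, which in this assay gives 110 nM, and the step of a 7.6-fold higher number from compound 1 to compound 2 (0.88 log units; beyond the scatter) separates the two. Compound 3 `COc1cc2c(Oc3ccc(NC(=O)c4cc(-c5ccc(C)cc5)nc5ccc(F)cc45)cc3F)ccnc2cc1OCCCN1CCC(C)CC1` differs from compound 2 by 4-methylphenyl in place of 3-methoxyphenyl on an aromatic carbon, next to the ring nitrogen of the shared core. Among the measured compounds shown here, no measured step exchanges one such phenyl substitution pattern for another directly; the only step that bears on it is a 7.6-fold higher number from compound 1 to compound 2 (0.88 log units; beyond the scatter), where loss of the chloro and entry of a methoxy went with the higher number. Taking the methoxy away again is therefore expected to move the number back toward that of compound 1, although the methyl has no measured precedent. Compound 3 is expected to give about 220 nM in this assay, with a range from 70 nM to 700 nM. That corresponds to an expected step of a 3.8-fold lower number from compound 2 to compound 3 (0.58 log units; beyond the scatter).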

Compound 3, half-maximal inhibitory concentration: 2000 nM
The estimate for compound 3 lay 9.1-fold (0.96 log units) below the measured number; measured number above the stated range.
By their numbers in this assay, from the lowest: compound 1; then compound 2; then compound 3.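

In this assay, taking the methoxy away did not bring the number back toward that of compound 1, as 4-methylphenyl in place of 3-methoxyphenyl gave a 2.4-fold higher number from compound 2 to compound 3 (0.38 log units; beyond the scatter) and 4-methylphenyl in place of 3-chlorophenyl gave an 18-fold higher number from compound 1 to compound 3 (1.26 log units; beyond the scatter). On this aromatic carbon, next to the ring nitrogen, the numbers therefore rise from 3-chlorophenyl through 3-methoxyphenyl to 4-methylphenyl, so the methoxy is not the sole feature that goes with a higher number. No evidence is available to explain this order.

Because compound 3 differs from the others in both the kind of substituent and its place on the phenyl ring, the two changes cannot be separated here; 3-methylphenyl or 4-chlorophenyl would tell them apart. Going by these compounds, how an unsubstituted phenyl, or a phenyl bearing an amine or a carboxylic acid, would read also remains open.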